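Cyano in Place of Tetrazolyl on a Sulfonamide Core

A few compounds are considered here, and "the series" means these few. Any claim that something is new, unique, unknown or untested is made for them only; others in the source may bear on it.

Compound 1 `O=[N+]([O-])c1ccccc1NS(=O)(=O)c1ccccc1`: 22900 nM
Compound 2 `Cc1ccc(-c2nnn[nH]2)c(NS(=O)(=O)c2ccc(F)cc2)c1`: > 100000 nM

Of the compounds shown here, two have been measured in a functional assay on PC-3 cells (Homo sapiens) for cytotoxicity, read by MTT assay, with a stated time of 5 days; a lower number here means a stronger inhibitor of growth, a higher number a weaker inhibitor of growth. Compound 1 gives 22900 nM in this assay. For compound 2 this assay reports only a limit, > 100000 nM, so where compound 2 stands is known only as lying at the limit of > 100000 nM in this assay, at which 1 of the 2 values shown sits, without a number. Compound 3 `Cc1ccc(C#N)c(NS(=O)(=O)c2ccc(F)cc2)c1` differs from compound 2 by cyano in place of 1H-tetrazol-5-yl on an aromatic carbon. No measured step of this kind exists among the two compounds shown, so the size of the change in this assay cannot be read from them. In this assay compound 3 is expected to give 50000 nM, estimated between 10000 nM and 200000 nM. The step of an at least 2.0-fold lower number from compound 2 to compound 3 (0.30 log units; that floor lies within the scatter) is thus an expectation of a modest move toward a stronger inhibitor, though a result that again reaches the limit is held to be almost as likely.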

Compound 3, concentration for 50% growth inhibition: 100000 nM
Compound 3: the middle estimate sits 2.0-fold (0.30 log units) below what was measured, within the range that was stated.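

In this assay compound 3 gives 100000 nM, so the smaller cyano group, which has no ring and no hydrogen-bond donor, yields a measured number at this aromatic carbon on the shared core. Compound 2 is held only by a limit of the assay: the limit of > 100000 nM in this assay, at which 1 of the 3 values shown sits. Replacing 1H-tetrazol-5-yl with cyano gives a number no higher from compound 2 to compound 3 (the limit leaves the size open), so the result shows no measurable gain from this change.

The compounds shown leave open whether a carboxylic acid or an amine on this aromatic carbon would give a lower number than compound 3. They also leave open whether the cyano result would hold with a chloro group in place of the methyl group.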